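Replacing the diethylamino group of compound 3

This account rests on a few compounds, and the source may have more. Where it says the series, first, only, none or still open, it means among the compounds named here.

In a functional assay on HL-60 cells (Homo sapiens) for inhibition, read by MTT assay, with a stated time of 48 h, tested at 10 uM (a higher number here means more inhibition of growth at the concentration tested, a lower number less inhibition of growth), compound 3 (`CCN(CC)Cc1c(O)c([C@H]2CCN(C)C[C@H]2O)c2oc(C)cc(=O)c2c1O`) stands highest of the three measured compounds, at 47%. Compound 2 (`Cc1cc(=O)c2c(O)cc(OC/C=C/c3ccccc3)c([C@H]3CCN(C)C[C@H]3O)c2o1`) gives 21% and compound 1 (`Cc1cc(=O)c2c(O)cc(OCc3ccccc3Br)c([C@H]3CCN(C)C[C@H]3O)c2o1`) gives 3%, both well beyond the scatter from compound 3.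

Compound 4 (`Cc1cc(=O)c2c(O)c(CN3CCCC3CO)c(O)c([C@H]3CCN(C)C[C@H]3O)c2o1`) keeps the shared core of compound 3 and alters only the amine: 2-(hydroxymethyl)pyrrolidin-1-yl in place of diethylamino on a saturated chain carbon bound to an aromatic carbon. Among the measured compounds shown here, the one measured step, a number 18 percentage points higher from compound 1 to compound 2 (beyond the scatter), was modest, but it lies on a saturated chain carbon bound to an oxygen on an aromatic ring and involves other groups. It therefore bears only loosely on this change, showing a shift of modest size among close relatives. For the measured compounds named here, no measured step covers a change at the chain carbon bound to an aromatic carbon, so the direction remains open. The estimated step is a number 7 percentage points lower from compound 3 to compound 4 (within the scatter), and no change beyond the scatter is expected. For compound 4 the estimated value is 40%, with an expected range of 18% to 62%.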

Compound 4, percent growth inhibition at one concentration: 33%
Compound 4: the middle estimate sits 7 percentage points above what was measured; measured number inside the range.
By their numbers in this assay, from the lowest: compound 1; then compound 2; then compound 4; then compound 3.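

Among the compounds shown here, at the saturated chain carbon bound to an aromatic carbon, the earlier compounds offered no step, and this assay now records a number 14 percentage points lower from compound 3 to compound 4 (beyond the scatter) when 2-(hydroxymethyl)pyrrolidin-1-yl enters in place of diethylamino. The amine at this position therefore affects the read-out, yet the change does not abolish growth inhibition, since compound 4 still gives 33% at the concentration tested. Nothing measured here bears on why the number fell.

This single step closes the amine into a ring and adds a hydroxymethyl group at once, leaving the two changes inseparable; plain pyrrolidin-1-yl at the same place would tell them apart. As far as these compounds go, how a piperidine, a morpholine or a longer chain on the nitrogen would read at this position also remains open.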